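From compound 1 to compound 4: changing the aryl group

A few compounds are considered here, and "the series" means these few. Any claim that something is new, unique, unknown or untested is made for them only; others in the source may bear on it.

In a functional assay on HT-29 cells (Homo sapiens) for antiproliferative activity, read by MTT assay, with a stated time of 48 h (on this read-out lower numbers stand for stronger inhibition of growth and higher numbers for weaker inhibition of growth), compound 1 `COC(=O)N1N=C(c2cccc(O)c2)CC1c1cc(OC)c(OC)c(OC)c1` gives 1350 nM, the lowest number among the series. Compound 2 `CCCOC(=O)N1N=C(c2cccc(O)c2)CC1c1cc(OC)c(OC)c(OC)c1` gives 15200 nM, and the change is large: an 11-fold higher number from compound 1 to compound 2 (1.05 log units; beyond the scatter). Compound 3 `COc1cc(C2CC(c3cccc(O)c3)=NN2C(=O)OCc2ccccc2)cc(OC)c1OC` reports only a limit, > 10000 nM. The step to that limit is at least modest: an at least 7.4-fold higher number from compound 1 to compound 3 (0.86 log units; beyond the scatter).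

Compound 4 `COC(=O)N1N=C(c2ccc(OC)c(OC)c2)CC1c1cc(OC)c(OC)c(OC)c1` carries 3,4-dimethoxyphenyl in place of 3-hydroxyphenyl on a carbon with a double bond to nitrogen. Among the measured compounds shown here, no measured step touches this place. Both measured steps from compound 1 lie on a saturated chain carbon bound to an oxygen next to a carbonyl group, so they bear on the new change only indirectly. They show that both changes made to compound 1 raised the number, by an 11-fold higher number from compound 1 to compound 2 (1.05 log units; beyond the scatter) in the better-defined case. A moderate rise in this assay is therefore expected, with wide uncertainty. The expected step is a 2.2-fold higher number from compound 1 to compound 4 (0.35 log units; beyond the scatter). The estimate for compound 4 is 3000 nM, with an expected range of 700 nM to 13000 nM.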

Compound 4, concentration for 50% growth inhibition: 9200 nM
Beside the measured number, compound 4's estimate is 3.1-fold (0.49 log units) below it; low and high end bracket the measured number.
By their numbers in this assay, from the lowest: compound 1; then compounds 4 and 2 (each within the scatter of the next).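

The aryl group on the carbon with a double bond to nitrogen is now a second place where a change to compound 1 raises the number, so sensitivity is not confined to the methoxycarbonyl group: in this assay the replacement of 3-hydroxyphenyl by 3,4-dimethoxyphenyl gives a 6.8-fold higher number from compound 1 to compound 4 (0.83 log units; beyond the scatter). Compound 1 keeps the lowest number in the series, and neither place has yet yielded a change that lowers it. Nothing measured here accounts for this step.

The change removes the hydroxyl and adds two methoxy groups in one move, so the compounds shown do not separate the effect of losing the one from that of gaining the others. Also open, going by these compounds, is how an amine or a carboxylic acid on this phenyl ring would read in this assay.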